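A few compounds are considered here, and "the series" means these few. Any claim that something is new, unique, unknown or untested is made for them only; others in the source may bear on it.

In a functional assay on MCF7 cells (Homo sapiens) for cytotoxicity, read by MTT assay, with a stated time of 48 h (on this read-out higher numbers stand for weaker inhibition and lower numbers for stronger inhibition), compound 1 (`C#CCNC(=O)Nc1cccc(CNCc2ccccc2)c1`) gives 343000 nM and compound 2 (`C#CCNC(=O)Nc1cccc(CNCc2ccc(OC(F)(F)F)cc2)c1`) gives 283000 nM as its half-maximal inhibitory concentration. Within the data shown here, these two values lie within the scatter of each other, so compound 2 stands level with compound 1, the only other compound measured so far. Compound 3 (`C#CCNC(=O)Nc1cccc(CNCc2ccc(OC)cc2)c1`) still awaits measurement. It differs from compound 2 by a single exchange, methyl in place of trifluoromethyl on an oxygen on an aromatic ring, which turns trifluoromethoxy to methoxy. Among the measured compounds shown here, no measured compound carries methoxy, so the evidence is indirect. For the measured compounds named here, the one measured step that bears on the change, trifluoromethoxy in place of hydrogen on an aromatic carbon, gave a 1.2-fold lower number from compound 1 to compound 2 (0.08 log units; within the scatter) and on that ground no step beyond the scatter is expected in this assay in either direction. The estimate therefore means a 1.1-fold higher number from compound 2 to compound 3 (0.03 log units; within the scatter) as the expected change. Compound 3 is expected at an estimated 300000 nM with a range from 150000 nM to 600000 nM on this read-out.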

Compound 3, half-maximal inhibitory concentration: 195000 nM
Compound 3: the middle estimate sits 1.5-fold (0.19 log units) above what was measured; the range from low to high includes it.
By their numbers in this assay, from the lowest: compounds 3, 2 and 1 (each within the scatter of the next).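

In this assay, methyl in place of trifluoromethyl on an oxygen on an aromatic ring brings a 1.5-fold lower number from compound 2 to compound 3 (0.16 log units; within the scatter) and so does not separate the two groups at this place. Among these compounds, compound 3 also gives the first reading for methoxy against hydrogen, with a 1.8-fold lower number from compound 1 to compound 3 (0.25 log units; within the scatter) as a step that likewise stays inside the scatter, so that compounds 1, 2 and 3 cannot be told apart in this assay, whichever of the three groups the aromatic ring carries. Nothing at hand bears on why the values of these compounds lie where they do.

The compounds shown leave open whether any group on this aromatic ring can produce a step beyond the scatter, for instance an amine, a carboxylic acid or a nitrile, or whether a longer chain such as ethyl or propyl in place of methyl on the same oxygen would do so. They also leave open whether a change elsewhere in the shared core, rather than on this ring, would move the number any further than these exchanges have.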